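One More Methoxy Group: From Compound 1 to Compound 4

The source may hold more compounds than are shown below. What is called first, only, known or untested is meant among the compounds shown, and "the series" means these compounds.

Measured so far:
Compound 1 `COc1ccc(C(=O)NNC(=O)c2ccc3[nH]c(-c4ccc([N+](=O)[O-])o4)nc3c2)cc1OC`: 15.6 ug/mL
Compound 2 `O=C(NNC(=O)c1cc2ccccc2cc1O)c1ccc2[nH]c(-c3ccc([N+](=O)[O-])s3)nc2c1`: 62.5 ug/mL
Compound 3 `COc1cccc(C(=O)NNC(=O)c2ccc3[nH]c(-c4ccc([N+](=O)[O-])s4)nc3c2)c1`: 62.5 ug/mL

In a functional assay on DU-145 cells (Homo sapiens) for inhibition, read by sulforhodamine B assay, with a stated time of 48 h (on this read-out higher numbers stand for weaker inhibition of growth and lower numbers for stronger inhibition of growth), compound 1 stands lowest of the three numbers, so it is the strongest growth inhibitor in this set; compound 2 and compound 3 each sit well beyond the scatter above it. The unmeasured compound 4 `COc1cc(C(=O)NNC(=O)c2ccc3[nH]c(-c4ccc([N+](=O)[O-])o4)nc3c2)cc(OC)c1OC` keeps the shared core of compound 1 and differs from it only in the group attached to the carbonyl carbon: methoxy in place of hydrogen on an aromatic carbon.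

Among the compounds with values here, only one measured step touches the same region. The step of no change at the digits printed from compound 2 to compound 3 (within the scatter) replaces the whole group on that carbonyl carbon and leaves the number unchanged, which suggests this part of the molecule tolerates variation. Within the data shown here, no measured pair adds a methoxy group to an already substituted ring, so that step bears on compound 4 only loosely. The expectation is therefore a change of no change at the digits printed from compound 1 to compound 4 (within the scatter), that is, none beyond the scatter. Compound 4 is estimated at 15.6 ug/mL, with a likely range from 7 ug/mL to 35 ug/mL.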

Compound 4, concentration for 50% growth inhibition: 15.6 ug/mL
Compound 4: the middle estimate sits on the measured number at the digits printed; the range from low to high includes it.
By their numbers in this assay, from the lowest: compounds 1 and 4 (each within the scatter of the next); then compounds 2 and 3 (each within the scatter of the next).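

In this assay methoxy in place of hydrogen on an aromatic carbon brings no change at the digits printed from compound 1 to compound 4 (within the scatter) and so leaves growth inhibition where it stood. Within the data shown here, the one earlier step swapped the whole group on the carbonyl carbon, whereas this pair holds the shared core fixed and changes a single ring position, ortho to a methoxy group and meta to a large group. It shows that this position takes one more methoxy group without a change in the number, though nothing given here explains why.

From the compounds shown here alone, whether the position is as tolerant of other groups stays open, since an amine or a carboxylic acid there could give a very different number. The compounds shown also leave open whether a longer chain, such as propoxy, would fare like methoxy.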